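Propanoyl in Place of Acetyl on a Second Core

A few compounds are considered here, and "the series" means these few. Any claim that something is new, unique, unknown or untested is made for them only; others in the source may bear on it.

Compound 1 `CCC(=O)N1CCCC(NS(=O)(=O)c2ccc(F)cc2)C1` gives 10 mg/kg in a functional assay on the whole organism with Mus musculus as the target, with a stated time of 30 min; a higher number here means that more compound is needed for the effect, a lower number that less compound is needed. Compound 2 `CC(=O)NCC1CCCN(S(=O)(=O)c2ccc(F)cc2)C1` gives 10 mg/kg in this assay. Compound 3 `CC(=O)N1CCCC(NS(=O)(=O)c2ccc(F)cc2)C1` gives 1 mg/kg in this assay.

Compound 3 and compound 1 share a core and differ only by methyl in place of hydrogen on a saturated chain carbon bound to a carbonyl carbon. That change brought a 10-fold higher number from compound 3 to compound 1 (1.00 log units; beyond the scatter), a step that a reader should weigh as a single observation.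

Compound 4 `CCC(=O)NCC1CCCN(S(=O)(=O)c2ccc(F)cc2)C1` has not yet been measured in this assay. It carries the same change, (methyl in place of hydrogen on a saturated chain carbon bound to a carbonyl carbon), set on the core of compound 2. The difference between the core of compound 2 and the core of compound 3 is not broken down here, so how the cores relate is left open. Compound 2 stands level with compound 1 at the digits given and apart from compound 3 by the gap already described.

Among the measured compounds shown here, because the one precedent, a 10-fold higher number from compound 3 to compound 1 (1.00 log units; beyond the scatter), went toward a higher number, compound 4 is expected to need more compound than compound 2, with an estimated step of a 3.0-fold higher number from compound 2 to compound 4 (0.48 log units; beyond the scatter). Compound 4 is estimated at 30 mg/kg, within 8 mg/kg to 100 mg/kg.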

Compound 4, minimum effective dose: 10 mg/kg
Beside the measured number, compound 4's estimate is 3.0-fold (0.48 log units) above it, within the range that was stated.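

In this assay the change from acetyl to propanoyl on the core of compound 2 gave no change at the digits printed from compound 2 to compound 4 (within the scatter) and so did not repeat the step seen on the core of compound 3. Set side by side, the two steps differ, so in these two pairs the result of this change did not carry from one core to the other: the same change on two cores in this assay, a 10-fold higher number (1.00 log units; beyond the scatter) from compound 3 to compound 1 and no change at the digits printed (within the scatter) from compound 2 to compound 4, 10-fold (1.00 log units) apart, beyond the scatter of two such steps. This shows that the same change can read differently on these two cores, but it does not show which difference between the cores is responsible, and two pairs give no rule for any further core.

The compounds shown leave open whether a longer chain such as butanoyl would widen the gap between the two cores or close it. They also leave open how either core would respond to an amine or a carboxylic acid at the end of that chain.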